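This account rests on a few compounds, and the source may have more. Where it says the series, first, only, none or still open, it means among the compounds named here.

Measured so far in a functional assay for inhibition of sodium/hydrogen exchanger (Oryctolagus cuniculus); on this read-out lower numbers stand for stronger inhibition and higher numbers for weaker inhibition:
compound 1 `CCCc1cc(C)c(C(=O)N=C(N)N)cc1S(C)(=O)=O` gives 5.7 nM
compound 2 `Cc1cc(-c2ccc(F)cc2)c(S(C)(=O)=O)cc1C(=O)N=C(N)N` gives 36 nM
compound 3 `CCSc1cc(C)c(C(=O)N=C(N)N)cc1S(C)(=O)=O` gives 5.9 nM

Compound 3 stands second highest of the three numbers. Its nearest neighbour is compound 1, separated by a 1.0-fold higher number from compound 1 to compound 3 (0.01 log units; within the scatter), a gap within the scatter, so no order between compounds 1 and 3 can be read. The furthest is compound 2, separated by a 6.1-fold lower number from compound 2 to compound 3 (0.79 log units; beyond the scatter).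

Compound 4 `Cc1cc(O)c(S(C)(=O)=O)cc1C(=O)N=C(N)N` has not yet been measured. It differs from compound 3 in one place: hydroxy in place of ethylsulfanyl on an aromatic carbon. Ethylsulfanyl leaves and hydroxy enters on an aromatic carbon, ortho to a methylsulfonyl group and para to a group of 6 heavy atoms.

For the measured compounds named here, no measured step brings in a hydroxy group. The steps at this same aromatic carbon are a 1.0-fold higher number from compound 1 to compound 3 (0.01 log units; within the scatter), within the scatter, and a 6.3-fold higher number from compound 1 to compound 2 (0.80 log units; beyond the scatter), a modest loss. Propyl and ethylsulfanyl gave about the same number; 4-fluorophenyl gave a weaker one. Hydroxy resembles none of these, so the bearing of the steps is loose, and the uncertainty is wide. A modest step toward a higher number is expected for compound 4, a 2.5-fold higher number from compound 3 to compound 4 (0.41 log units; beyond the scatter). Compound 4 is estimated at 15 nM, with a range from 4 nM to 60 nM.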

Compound 4, half-maximal inhibitory concentration: 220 nM
For compound 4 the middle estimate is 15-fold (1.17 log units) below the measured one; the whole stated range lies below it.
By their numbers in this assay, from the lowest: compounds 1 and 3 (each within the scatter of the next); then compound 2; then compound 4.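

In this assay, for the compounds shown here, this aromatic carbon, para to a group of 6 heavy atoms, proves much less permissive than the earlier compounds indicated: hydroxy gives a 37-fold higher number from compound 3 to compound 4 (1.57 log units; beyond the scatter) and a 39-fold higher number from compound 1 to compound 4 (1.59 log units; beyond the scatter), both large steps, whereas propyl and ethylsulfanyl could not be told apart. The 4-fluorophenyl group, previously the poorest group here, also fares better than hydroxy, with a 6.1-fold higher number from compound 2 to compound 4 (0.79 log units; beyond the scatter), so across these four compounds the number does not rise with the heavy-atom count of the group, and the group with the fewest heavy atoms gives the weakest inhibition. Nothing on hand accounts for this loss.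

From the compounds shown here alone, whether the loss follows from the hydrogen-bond donor that enters with hydroxy or from having an oxygen atom on this carbon remains open, and a methoxy group would help separate the two. An amine at the same carbon would test whether another small group carrying a hydrogen-bond donor behaves like hydroxy, while a longer chain would show how far the tolerance seen with propyl extends.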